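A few compounds are considered here, and "the series" means these few. Any claim that something is new, unique, unknown or untested is made for them only; others in the source may bear on it.

Measured so far in an ADME assay on L132 cells (Homo sapiens) for cytotoxicity, read by MTT assay, with a stated time of 72 h; on this read-out higher numbers stand for weaker inhibition and lower numbers for stronger inhibition:
compound 1 `COC(=O)c1cc(C2=C(c3cc(OC)c(OC)c(OC)c3)C(=O)CC2O[SiH2]C(C)(C)C)ccc1OC`: > 100 ug/mL (a limit)
compound 2 `COc1ccc(C2=C(c3cc(OC)c(OC)c(OC)c3)C(=O)CC2O)cc1O`: < 1 ug/mL (a limit)
compound 3 `COc1cc(C2=C(c3ccccc3)C(O[SiH2]C(C)(C)C)CC2=O)cc(OC)c1OC`: > 100 ug/mL (a limit)

Compound 3 gives only a limit and stands at the limit of > 100 ug/mL in this assay, at which 2 of the 3 values shown sit. Among the measured compounds shown here, the one measured step, a step that the two limits leave unreadable from compound 1 to compound 3, offers no size to carry over. Going to compound 4 `COc1ccc(C2=C(c3cc(OC)c(OC)c(OC)c3)C(=O)CC2O[SiH2]C(C)(C)C)cc1O` brings (3-hydroxy-4-methoxyphenyl in place of phenyl on a double-bonded ring carbon), that is, 3-hydroxy-4-methoxyphenyl in place of phenyl on a double-bonded ring carbon. Compound 2 carries this same group and gives < 1 ug/mL, again a limit, so a step towards stronger inhibition is expected in this assay, of a size that no limit can fix. The estimated step is an at least 10-fold lower number from compound 3 to compound 4 (1.00 log units; beyond the scatter), and it is uncertain. Compound 4 is expected at 10 ug/mL, within an estimated range of 1 ug/mL to 100 ug/mL.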

Compound 4, half-maximal inhibitory concentration: < 1 ug/mL
Compound 4 was reported as a limit; the forecaster's own chance of this, stated with the estimate: 45%; middle value at least 10-fold (1.00 log units) away from the limit.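

In this assay, 3-hydroxy-4-methoxyphenyl in place of phenyl on a double-bonded ring carbon gives an at least 100-fold lower number from compound 3 to compound 4 (2.00 log units; beyond the scatter), so the group at this position can decide between the two limits of the assay. Hydroxy in place of methoxycarbonyl on an aromatic carbon gives an at least 100-fold lower number from compound 1 to compound 4 (2.00 log units; beyond the scatter), which shows that the group of 5 heavy atoms on the oxygen, shared by compound 1, compound 3 and compound 4, does not by itself rule out strong inhibition. The step between compound 2 and compound 4 cannot be read, since both values are limits.

As far as these compounds go, how far compound 2 and compound 4 lie past their limit stays open. Also open, from the compounds shown here alone, is whether an amine in place of the hydroxy would keep this strength.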